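Extending the chain on two related urea and amide cores

The compounds below may be only part of what the source reports. "The series", "measured", "known", "first", "only" and "open" are said of these compounds alone.

Compound 1, `CCNC(=O)Nc1cccc2c1CN(C)CC2c1ccccc1`, gives 80 mg/kg in a functional assay on the whole organism for inhibition, with Mus musculus as the target; on this read-out higher numbers stand for an effect only at larger amounts of compound and lower numbers for an effect already at smaller amounts.
Compound 2, `CCCCNC(=O)Nc1cccc2c1CN(C)CC2c1ccccc1`, gives about 40 mg/kg in this assay.
Compound 3, `CCNCC(=O)Nc1cccc2c1CN(C)CC2c1ccc(C)cc1`, gives about 45 mg/kg in this assay.

The three measured compounds share a bicyclic amine core carrying a phenyl group, and they differ in the side chain attached to the aromatic ring. Compound 1 and compound 2 are separated by a single change, (ethyl in place of hydrogen on a saturated chain carbon, two bonds along the chain from an amide-type nitrogen). This change gave a 2.0-fold lower number from compound 1 to compound 2 (0.30 log units; within the scatter), a step that lies within the usual scatter of the assay and so does not by itself show a real gain.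

Compound 3 belongs to a related series; how its core differs from the core of compound 1 is not broken down here, and the two values show only that compound 3 and compound 1 lie within the scatter of each other.

The unmeasured compound 4, `CCCCNCC(=O)Nc1cccc2c1CN(C)CC2c1ccc(C)cc1`, is derived from compound 3 by ethyl in place of hydrogen on a saturated chain carbon, two bonds along the chain from an amine nitrogen. For the measured compounds named here, this is the same kind of change as the one between compound 1 and compound 2, but the surroundings differ: in the first pair the chain carbon sits two bonds from an amide-type nitrogen, whereas in compound 4 it sits two bonds from an amine nitrogen. The expectation is that compound 4 behaves as compound 2 did relative to compound 1, giving an estimated step of a 1.6-fold lower number from compound 3 to compound 4 (0.21 log units; within the scatter), because the earlier change produced a 2.0-fold lower number from compound 1 to compound 2 (0.30 log units; within the scatter). Compound 4 is therefore expected to fall near 28 mg/kg, with a plausible range from 14 mg/kg to 60 mg/kg.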

Compound 4, dose for half-maximal effect: 34 mg/kg
For compound 4 the middle estimate is 1.2-fold (0.08 log units) below the measured one; the measured number falls inside the stated range.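

Replacing hydrogen with ethyl on the saturated chain carbon, which turns the ethylamino group of compound 3 into the butylamino group of compound 4, gives in this assay a 1.3-fold lower number from compound 3 to compound 4 (0.12 log units; within the scatter) and so cannot be told apart from the ordinary spread of repeated measurements. Set beside the same change on the other core, the two steps cannot be told apart either, so on this read-out the change looks much the same in both settings: the same change on two cores in this assay, a 2.0-fold lower number (0.30 log units; within the scatter) from compound 1 to compound 2 and a 1.3-fold lower number (0.12 log units; within the scatter) from compound 3 to compound 4, 1.5-fold (0.18 log units) apart, within the scatter of two such steps. This agreement is modest support at best: neither step on its own shows a real gain, two small steps can match by chance, and two pairs say nothing about how the change would behave on any other core.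

The compounds shown stop at the butyl chain, so it remains open whether a longer chain such as hexyl would give a step large enough to stand clear of the scatter. Also open, on these data alone, is what a chain ending in a carboxylic acid or a phenyl ring would do on either core, and whether such a change would again give similar steps on both.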